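Chloro for methoxy: from compound 3 to compound 4

This account rests on a few compounds, and the source may have more. Where it says the series, first, only, none or still open, it means among the compounds named here.

Three compounds have been measured in an assay on isolated protein for inhibition of beta-glucuronidase (Bos taurus), read by spectrophotometry, with a stated time of 30 min; on this read-out lower numbers stand for stronger inhibition and higher numbers for weaker inhibition:
Compound 1, `Cc1ccc(Nc2nnc(-c3ccccc3Cl)s2)cc1`, gives 16700 nM.
Compound 2, `COc1cc(OC)cc(-c2nnc(Nc3ccc(Cl)c(Cl)c3)s2)c1`, gives 19200 nM.
Compound 3, `COc1ccccc1-c1nnc(Nc2ccc(Cl)c(Cl)c2)s1`, gives 22600 nM.

Compound 3 carries the highest of the three numbers, yet its gaps to compound 2 and to compound 1 both lie within the usual scatter, so the three stand level in this assay. Compound 4, `Clc1ccc(Nc2nnc(-c3ccccc3Cl)s2)cc1Cl`, differs from compound 3 by chloro in place of methoxy on an aromatic carbon. Within the data shown here, no two measured compounds differ in one place, so no step is available to lean on. The three measured values sit close together, and compound 1, which carries the same chloro group, gives 16700 nM. On that basis the step of a 1.5-fold lower number from compound 3 to compound 4 (0.18 log units; within the scatter) is expected to stay within the scatter. Compound 4 is estimated at 15000 nM, with a range of 5000 nM to 45000 nM.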

Compound 4, half-maximal inhibitory concentration: 2160 nM
For compound 4 the middle estimate is 6.9-fold (0.84 log units) above the measured one; the measured number lies below the stated range.
By their numbers in this assay, from the lowest: compound 4; then compounds 1, 2 and 3 (each within the scatter of the next).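

Up to this point the three compounds stood level in this assay and offered no single change to read. Chloro in place of methoxy on an aromatic carbon, ortho to a large group, now gives a 10-fold lower number from compound 3 to compound 4 (1.02 log units; beyond the scatter), which shows that the group at this position can matter a great deal in this series. Nothing at hand accounts for the size of this step.

From the compounds shown here alone, whether the gain belongs to chloro itself stays open, since fluoro, bromo, methyl or an amine at this position could show either a similar or a different result. Going by these compounds, it is also open whether the same change would give a step of this size on a different core.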